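Adding a second fluorine to the outer ring of compound 1

The compounds below may be only part of what the source reports. "The series", "measured", "known", "first", "only" and "open" are said of these compounds alone.

Compound 1, `CCS(=O)(=O)N(Cc1ccc(-c2cccc(F)c2)cc1)[C@@H](C)C(=O)N[C@H](C#N)CC(N)=O`: in an assay on isolated protein for inhibition of legumain (Homo sapiens), with stated times of 2 min and 60 min (a lower number here means a stronger inhibitor, a higher number a weaker inhibitor), compound 1 gives 3890 nM.
Compound 2, `CC(C)CS(=O)(=O)N(Cc1ccc(-c2cccc(F)c2)cc1)[C@@H](C)C(=O)N[C@H](C#N)CC(N)=O`: compound 2 gives 2270 nM.
Compound 3, `CCCS(=O)(=O)N(Cc1ccc(-c2cccc(F)c2)cc1)[C@@H](C)C(=O)N[C@H](C#N)CC(N)=O`: compound 3 gives > 10000 nM, which is a limit of this assay rather than a number.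

Among the two actual numbers, compound 1 has the higher one; its nearest neighbour is compound 2, and the step of a 1.7-fold lower number from compound 1 to compound 2 (0.23 log units; within the scatter) lies within the scatter, so the two cannot be ranked. Compound 3 sits at the limit (the limit of > 10000 nM in this assay, at which 1 of the 3 values shown sits).

The unmeasured compound 4, `CCS(=O)(=O)N(Cc1ccc(-c2cccc(F)c2F)cc1)[C@@H](C)C(=O)N[C@H](C#N)CC(N)=O`, differs from compound 1 in one place: fluoro in place of hydrogen on an aromatic carbon. All three measured steps concern the chain on the sulfonyl sulfur, namely a 1.7-fold lower number from compound 1 to compound 2 (0.23 log units; within the scatter), an at least 2.5-fold higher number from compound 1 to compound 3 (0.41 log units; beyond the scatter) and an at least 4.4-fold higher number from compound 2 to compound 3 (0.64 log units; beyond the scatter). None of them touches the ring where the new fluoro enters, so they give no direct guide to the size or direction of this change.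

With nothing to point either way, compound 4 is expected to stay close to compound 1, with a step of a 1.1-fold lower number from compound 1 to compound 4 (0.05 log units; within the scatter) that is not expected to exceed the scatter. The estimate for compound 4 in this assay is 3500 nM, expected to fall between 1400 nM and 9000 nM.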

Compound 4, half-maximal inhibitory concentration: 1090 nM
Compound 4: middle estimate off by 3.2-fold (0.51 log units), on the high side, and the stated range ends above it.
By their numbers in this assay, from the lowest: compound 4; then compounds 2 and 1 (each within the scatter of the next). At a limit, above all of these: compound 3.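

In this assay, fluoro in place of hydrogen on an aromatic carbon, which turns 3-fluorophenyl into 2,3-difluorophenyl, gives a 3.6-fold lower number from compound 1 to compound 4 (0.55 log units; beyond the scatter), so this single added atom makes compound 4 a stronger inhibitor by more than the usual scatter of the measurement. Going by these compounds alone, the earlier steps all concerned the chain on the sulfonyl sulfur, so this is the first sign that the outer ring also matters, and that a change there, on a carbon ortho to a fluoro group and ortho to a large group, can improve inhibition of legumain. The compounds shown offer no measurement that explains the size or direction of this step.

From the compounds shown here alone, it remains open whether this gain is particular to fluoro: a chloro, methyl or methoxy group on the same aromatic carbon would test whether other groups are tolerated there, and fluoro on the other carbons of this ring would show whether the position itself matters. Going by these compounds, it is also open whether the same ring change would give a similar step when combined with the sulfonyl chain of compound 2, which would show whether the two parts of the molecule act independently.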